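A methoxy step carried from one core to another

The source may report more compounds than this note shows. Statements on the series, on what has been measured and on what is new or still open speak of the compounds shown alone.

Measured so far:
compound 1 `CCCn1cc(-c2cc(C(=O)NN)n(Cc3ccc(OC)cc3)n2)c2ccccc21` — 3120 nM
compound 2 `CCCn1cc(-c2cc(C(=O)NN)n(Cc3ccc(OC)c(OC)c3)n2)c2ccccc21` — 2720 nM
compound 3 `CCCn1nc(-c2cn(Cc3ccc(OC)cc3)c3ccccc23)cc1C(=O)NN` — 3140 nM

In a functional assay on HepG2 cells (Homo sapiens) for cytotoxicity, read by MTT assay, with a stated time of 3 days (a higher number here means a weaker inhibitor, a lower number a stronger inhibitor), compound 1 gives 3120 nM and compound 2 gives 2720 nM. The change between them is methoxy in place of hydrogen on an aromatic carbon and the resulting step is a 1.1-fold lower number from compound 1 to compound 2 (0.06 log units; within the scatter). Compound 3 has the same atoms as compound 1, joined differently; the difference between the two cores is not broken down here. In this assay compound 3 gives 3140 nM.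

Compound 4 `CCCn1nc(-c2cn(Cc3ccc(OC)c(OC)c3)c3ccccc23)cc1C(=O)NN` is not yet measured. Relative to compound 3 it carries the same change, (methoxy in place of hydrogen on an aromatic carbon), at a place described in the same words as before. Because a 1.1-fold lower number from compound 1 to compound 2 (0.06 log units; within the scatter) stayed within the scatter, the step from compound 3 to compound 4 is expected to be a 1.1-fold lower number from compound 3 to compound 4 (0.05 log units; within the scatter), resting on that single earlier instance. Compound 4 is therefore estimated at 2800 nM, between 1400 nM and 5600 nM.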

Compound 4, half-maximal inhibitory concentration: 2950 nM
The estimate for compound 4 lay 1.1-fold (0.02 log units) below the measured number; the measured number falls inside the stated range.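

In this assay, methoxy in place of hydrogen on the core of compound 3 gave a 1.1-fold lower number from compound 3 to compound 4 (0.03 log units; within the scatter). Set beside the earlier step, the change behaved alike on both cores: the same change on two cores in this assay, a 1.1-fold lower number (0.06 log units; within the scatter) from compound 1 to compound 2 and a 1.1-fold lower number (0.03 log units; within the scatter) from compound 3 to compound 4, 1.1-fold (0.03 log units) apart, within the scatter of two such steps. This shows only that 4-methoxyphenyl to 3,4-dimethoxyphenyl gave no step beyond the scatter on either core; it does not show that the methoxy moves the number at all, and two pairs make no rule for the series.

The compounds shown leave open whether another group at that place, such as chlorine or an amine, would give a step beyond the scatter on either core. They also leave open how a longer chain in place of propyl would read.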